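This account rests on a few compounds, and the source may have more. Where it says the series, first, only, none or still open, it means among the compounds named here.

Measured compounds:
Compound 1, `NC(=S)Nc1cccc(OCCCCCN2CCN(c3ccc(C4CCCCC4)cc3)C2=O)c1`, gives 12000 nM.
Compound 2, `NC(=S)Nc1cccc(OCCCCCN2CCN(c3ccc(Cl)c(Cl)c3)C2=S)c1`, gives only a limit, > 50000 nM.
Compound 3, `NC(=S)Nc1cccc(OCCCCCCCCNC(=S)Nc2cc(Cl)cc(Cl)c2)c1`, gives 12000 nM.

In an ADME assay on Huh-7 cells (Homo sapiens) for cytotoxicity (on this read-out higher numbers stand for lower toxicity in this test and lower numbers for higher toxicity in this test), compound 3 stands level with compound 1, whose value of 12000 nM lies within the usual scatter of the value of compound 3. Compound 2 is different only in that its result is the limit of > 50000 nM in this assay, at which 1 of the 3 values shown sits, a limit rather than a number. Compound 4, `CC(C)(C)c1ccc(NC(=S)NCCCCCCCCOc2cccc(NC(N)=S)c2)cc1`, is not yet measured and differs from compound 3 in one place: 4-(tert-butyl)phenyl in place of 3,5-dichlorophenyl on an amide-type nitrogen. Among the measured compounds shown here, no measured pair shows this change, so there is no direct precedent for its effect. The expectation is that the step from compound 3 to compound 4 stays within the scatter, no change at the digits printed from compound 3 to compound 4 (within the scatter). Compound 4 is therefore estimated at 12000 nM, between 4000 nM and 40000 nM.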

Compound 4, half-maximal cytotoxic concentration: 17000 nM
Compound 4: middle estimate off by 1.4-fold (0.15 log units), on the low side; the measured number falls inside the stated range.
By their numbers in this assay, from the lowest: compounds 1, 3 and 4 (each within the scatter of the next). At a limit, above all of these: compound 2.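

In this assay, among the compounds shown here, putting 4-(tert-butyl)phenyl in place of 3,5-dichlorophenyl on the amide-type nitrogen gives a 1.4-fold higher number from compound 3 to compound 4 (0.15 log units; within the scatter), the only direct reading of a change at this place. On this pair, the two aromatic groups cannot be told apart in this assay, even though one carries chlorine and the other only carbon. Nothing shown offers a reason for this result.

Going by these compounds, whether an aromatic ring carrying an amine or a carboxylic acid would read the same remains open. So does the effect of a longer chain between the two thiourea groups.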